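The source may report more compounds than this note shows. Statements on the series, on what has been measured and on what is new or still open speak of the compounds shown alone.

Measured so far, in an in vitro functional assay on Ltk cells for inhibition of metabotropic glutamate receptor 5 (Homo sapiens), read by calcium flux; a lower number here means a stronger inhibitor, a higher number a weaker inhibitor:
compound 1 `C(#Cc1ccccn1)C1=CCNCC1` gives 580 nM;
compound 2 `Cc1cccc(S(=O)(=O)N2CC=C(C#Cc3ccccn3)CC2)c1` gives 8.2 nM.

Of these two, compound 2 gives the lower number, and its gap to compound 1 lies well beyond the scatter. Compound 3 `O=S(=O)(c1ccc(Br)cc1)N1CC=C(C#Cc2ccccn2)CC1` differs from compound 2 in a single place: 4-bromophenyl in place of 3-methylphenyl on a sulfonyl sulfur. Among the measured compounds shown here, no measured pair of compounds shows what such an exchange does, so the expectation rests on compound 2 alone. The step of a 1.2-fold higher number from compound 2 to compound 3 (0.09 log units; within the scatter) is expected to be small, not clearly beyond the usual scatter in either direction. Compound 3 is therefore estimated at 10 nM in this assay, with a range from 3 nM to 40 nM.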

Compound 3, half-maximal inhibitory concentration: 2.2 nM
Compound 3: middle estimate off by 4.5-fold (0.66 log units), on the high side; measured number below the stated range.
By their numbers in this assay, from the lowest: compound 3; then compound 2; then compound 1.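

Within this assay putting 4-bromophenyl in place of 3-methylphenyl on the sulfonyl sulfur gives a 3.7-fold lower number from compound 2 to compound 3 (0.57 log units; beyond the scatter) and so shows that this position still tells two aromatic groups of equal heavy-atom count apart. Going by these compounds, the two groups differ in both the substituent and its ring position, so whether the bromine or its placement accounts for the step stays open. Also open, on these data alone, is how 4-methylphenyl, or a ring bearing an amine or a carboxylic acid, would compare at this sulfur. No available measurement bears on the reason for this step.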